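This account rests on a few compounds, and the source may have more. Where it says the series, first, only, none or still open, it means among the compounds named here.

Measured compounds:
- compound 1 `CC(C)(O)CN1CCC(c2nc(COc3ccc(/C=C4\CC(=O)NC4=O)cc3)cs2)CC1` — "not determined" (no result reported) in a functional assay on cells for agonist activity at Glucose-dependent insulinotropic receptor (Homo sapiens), read by a luciferase reporter, with a stated time of 6 h; a higher number here means that more compound is needed for the effect, a lower number that less compound is needed
- compound 2 `CC(C)(C)OC(=O)N1CCC(c2nc(COc3ccc(/C=C4\CC(=O)NC4=O)cc3)cs2)CC1` — "not determined" (no result reported) in this assay
- compound 3 `CC(C)(C)OC(=O)N1CCC(c2nc(COc3ccc(-n4cnnn4)cc3)cs2)CC1` — 103 nM in this assay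

Compound 2 stands without a number in this assay; no result was reported for it, and the same is true of compound 1, so two of the three measured compounds carry no figure at all. Only compound 3, which shares the protected piperidine and the thiazole-linked ether but carries a different terminal ring, gives a measured value, 103 nM.

Compound 4 `Cc1cc(/C=C2\CC(=O)NC2=O)ccc1OCc1csc(C2CCN(C(=O)OC(C)(C)C)CC2)n1` follows from compound 2 by a single change: methyl in place of hydrogen on an aromatic carbon, ortho to a large group and meta to a group of 8 heavy atoms. Among the measured compounds shown here, no step between two measured compounds with a number on both sides exists here, so there is nothing to read a size or a direction from. A change of this kind is expected to stay within the usual scatter, with no clear direction. For compound 4 the half-maximal effective concentration is estimated at 150 nM, with a range from 20 nM to 1500 nM.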

Compound 4, half-maximal effective concentration: 19 nM
Estimate against measurement, compound 4: 7.9-fold (0.90 log units) above; the measured number lies below the stated range.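

In this assay compound 2 has no single number, and the step to compound 4 cannot be read. No measurement shown here bears on this result. The compounds shown leave open what the methyl in place of hydrogen does in this assay.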